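The source may report more compounds than this note shows. Statements on the series, on what has been measured and on what is new or still open speak of the compounds shown alone.

Measured so far:
compound 1 `CC(=O)N1CCN(c2nc(=O)c3cc(C(F)(F)F)cc([N+](=O)[O-])c3s2)CC1`: 83.9 ug/mL
compound 2 `Cc1ccc(C(=O)N2CCN(c3nc(=O)c4cc(C(F)(F)F)cc([N+](=O)[O-])c4s3)CC2)cc1`: 6.7 ug/mL
compound 3 `CCCCC(=O)N1CCN(c2nc(=O)c3cc(C(F)(F)F)cc([N+](=O)[O-])c3s2)CC1`: 42.5 ug/mL

In a physicochemical assay for solubility, read by HPLC (on this read-out lower numbers stand for lower solubility and higher numbers for higher solubility), compound 3 stands second highest of the three numbers; its nearest neighbour is compound 1, a step of a 2.0-fold lower number from compound 1 to compound 3 (0.30 log units; within the scatter) away, within the scatter, while the furthest is compound 2, separated by a 6.3-fold higher number from compound 2 to compound 3 (0.80 log units; beyond the scatter), which lies beyond the scatter.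

Compound 4 `O=C(c1ccc(F)cc1)N1CCN(c2nc(=O)c3cc(C(F)(F)F)cc([N+](=O)[O-])c3s2)CC1` has not yet been measured in this assay. The change from compound 3 is 4-fluorophenyl in place of butyl on a carbonyl carbon. Of the measured steps, the one that bears most directly on it is a 6.3-fold higher number from compound 2 to compound 3 (0.80 log units; beyond the scatter), in which an aromatic ring on the carbonyl carbon gave way to a chain; the step from compound 4 back to an aromatic ring runs the other way. The step of a 13-fold lower number from compound 1 to compound 2 (1.10 log units; beyond the scatter) points in the same direction, a large loss on going from a small chain to an aromatic ring on that carbonyl carbon. Compound 4 is therefore expected to show a modest fall in this assay, a 5.3-fold lower number from compound 3 to compound 4 (0.73 log units; beyond the scatter), giving an estimated value of 8 ug/mL, with a range from 3 ug/mL to 20 ug/mL.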

Compound 4, solubility: 1.69 ug/mL
Estimate against measurement, compound 4: 4.7-fold (0.68 log units) above, and the stated range ends above it.
By their numbers in this assay, from the lowest: compound 4; then compound 2; then compounds 3 and 1 (each within the scatter of the next).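

In this assay, 4-fluorophenyl on the carbonyl carbon gives the lowest number of the series, well under both chains it can be set against: butyl (a 25-fold lower number from compound 3 to compound 4 (1.40 log units; beyond the scatter)) and methyl (a 50-fold lower number from compound 1 to compound 4 (1.70 log units; beyond the scatter)). Among these compounds, the earlier compounds showed only that one aromatic ring at this place lay below the chains, whereas this result shows that the aromatic compounds also differ among themselves, with fluoro in place of methyl on an aromatic carbon (a 4.0-fold lower number from compound 2 to compound 4 (0.60 log units; beyond the scatter)) giving a step beyond the scatter. Nothing measured here accounts for that further fall.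

The compounds shown leave open whether an amine or a carboxylic acid on the aromatic ring would raise the number again. They also do not show how a chloro group would compare with fluoro and methyl on that ring, or where a chain longer than butyl would fall.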